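This account rests on a few compounds, and the source may have more. Where it says the series, first, only, none or still open, it means among the compounds named here.

Measured compounds:
compound 1 `COc1cc(-c2cc(/C=C/C(=O)c3ccc(N)cc3)[nH]n2)cc(OC)c1OC`: -35%
compound 2 `COc1ccc(-c2cc(/C=C/C(=O)c3ccc(OC)c(OC)c3)[nH]n2)cc1`: -56%

In a functional assay on RPMI-8226 cells (Homo sapiens) for cytotoxicity, read by sulforhodamine B assay, with a stated time of 48 h, tested at 10 uM (on this read-out higher numbers stand for a weaker effect at the one concentration tested and lower numbers for a stronger effect), compound 1 gives -35%, the highest of the two numbers recorded. Compound 2 gives -56%, which lies below the value of compound 1 by more than the usual scatter. Within the data shown here, no two measured compounds differ in only one place, so the two values show only where each compound stands and do not tell how a single change on the carbonyl carbon plays out in this assay.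

Compound 3 `COc1cc(-c2cc(/C=C/C(=O)c3ccc(Cl)c(Cl)c3)[nH]n2)cc(OC)c1OC` has not yet been measured in this assay. It differs from compound 1 in one place: 3,4-dichlorophenyl in place of 4-aminophenyl on a carbonyl carbon. Among the measured compounds shown here, with no measured step for this kind of change, the step of a number 7 percentage points lower from compound 1 to compound 3 (within the scatter) is expected to be small, of a size close to the scatter, and its direction is open. For compound 3 the estimate in this assay is -42%, with a range from -70% to -12%.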

Compound 3, a percentage reported as activity, at one concentration (the size of the read-out at that concentration, not a potency): -7%
Beside the measured number, compound 3's estimate is 35 percentage points below it; measured number above the stated range.
By their numbers in this assay, from the lowest: compound 2; then compound 1; then compound 3.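

In this assay the group on the carbonyl carbon proves to matter: 3,4-dichlorophenyl in place of 4-aminophenyl gives a number 28 percentage points higher from compound 1 to compound 3 (beyond the scatter) and so a weaker effect at the one concentration tested. This is the only single change shown in the series, and on the core of compound 1 it places 4-aminophenyl ahead of 3,4-dichlorophenyl. No measurement at hand gives a reason for this step.

Among these compounds, the step cannot be assigned to the loss of the amine or to the arrival of the two chlorine atoms, since both occur in the one change. An unsubstituted phenyl, a 4-hydroxyphenyl or a 4-chlorophenyl on the same carbonyl carbon would separate the two, and the compounds shown say nothing about these groups.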